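Coumarin amides and an amine analogue in the same binding assay

The compounds below may be only part of what the source reports. "The series", "measured", "known", "first", "only" and "open" are said of these compounds alone.

Measured compounds:
Compound 1 `NC(=O)[C@@H]1CCCN1c1cc(=O)oc2cc(OCc3ccccc3)ccc12` — 99800 nM
Compound 2 `NC(=O)Cc1cc(=O)oc2cc(OCc3ccccc3)ccc12` — 8000 nM
Compound 3 `NC(=O)Cc1cc(=O)oc2cc(OCc3cccc(Cl)c3)ccc12` — 26000 nM

In a binding assay (strain Wistar) for inhibition of Amine oxidase [flavin-containing] A (Rattus norvegicus) (a higher number here means a weaker inhibitor, a lower number a stronger inhibitor), compound 2 gives 8000 nM, the lowest of the three numbers. Its nearest neighbour is compound 3, and the step of a 3.3-fold higher number from compound 2 to compound 3 (0.51 log units; beyond the scatter) lies beyond the scatter; the step of a 12-fold lower number from compound 1 to compound 2 (1.10 log units; beyond the scatter) is larger still. Compound 4 `CNCc1cc(=O)oc2cc(OCc3ccccc3)ccc12` has not yet been measured. It differs from compound 2 by methylamino in place of carbamoyl on a saturated chain carbon bound to an aromatic carbon. Neither measured step touches this position in the same way: one changes the whole side chain on the aromatic carbon, the other adds chloro on the benzyl ring. Both show, however, that the number is sensitive to changes around the shared core. Going by the values given here, with no direct precedent, a step of modest size in this assay is expected, with the direction uncertain and a weaker number somewhat more likely, so compound 4 is estimated at 12000 nM (range 2500 nM to 60000 nM), which would mean an expected step of a 1.5-fold higher number from compound 2 to compound 4 (0.18 log units; within the scatter).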

Compound 4, half-maximal inhibitory concentration: 15400 nM
Estimate against measurement, compound 4: 1.3-fold (0.11 log units) below; measured number inside the range.
By their numbers in this assay, from the lowest: compounds 2, 4 and 3 (each within the scatter of the next, the first and the last beyond it); then compound 1.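

Replacing carbamoyl with methylamino on a saturated chain carbon bound to an aromatic carbon gives a 1.9-fold higher number from compound 2 to compound 4 (0.28 log units; within the scatter), so this assay does not separate these two side chains. The (methylamino)methyl side chain also gives a 6.5-fold lower number from compound 1 to compound 4 (0.81 log units; beyond the scatter), which shows that a side chain without the carbamoyl group likewise stands clear of the 2-carbamoylpyrrolidin-1-yl group of compound 1. No supporting data bear on why these numbers fall as they do.

The compounds shown leave open how an unsubstituted aminomethyl group, a dimethylamino group, a carboxylic acid or a longer chain would read at this place. They also leave open whether chloro on the benzyl ring would act on compound 4 as it did in a 3.3-fold higher number from compound 2 to compound 3 (0.51 log units; beyond the scatter).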